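The source may report more compounds than this note shows. Statements on the series, on what has been measured and on what is new or still open speak of the compounds shown alone.

Among the measured compounds shown here, in a functional assay on U-251 cells (Homo sapiens) (a higher number here means a weaker inhibitor of growth, a lower number a stronger inhibitor of growth), compound 3 `O=S(=O)(/C=C/c1ccc(Cl)cc1Cl)Cc1ccc(Nc2ncnc3ccccc23)cc1` gives 4000 nM, the lowest of the three numbers so far. Compound 1 `O=S(=O)(/C=C/c1ccc(Cl)c(Cl)c1)Cc1ccc(Nc2ncnc3ccccc23)cc1` gives 11000 nM and compound 2 `O=S(=O)(/C=C/c1ccc(Cl)cc1)Cc1ccc(Nc2ncnc3ccccc23)cc1` gives 49000 nM. Compound 4 `O=S(=O)(/C=C/c1ccc(C(F)(F)F)cc1F)Cc1ccc(Nc2ncnc3ccccc23)cc1`, not yet measured, carries 2-fluoro-4-(trifluoromethyl)phenyl in place of 2,4-dichlorophenyl on a double-bonded chain carbon bound to a double-bonded chain carbon. For the measured compounds named here, two measured steps bear on this ring: adding one chloro brought a large change, a 12-fold lower number from compound 2 to compound 3 (1.09 log units; beyond the scatter), and rearranging the two chloro groups a modest one, a 2.8-fold lower number from compound 1 to compound 3 (0.44 log units; beyond the scatter). Neither step introduces fluoro or trifluoromethyl, so only a modest move toward a higher, weaker number is expected in this assay. The expected step is a 2.0-fold higher number from compound 3 to compound 4 (0.30 log units; within the scatter). For compound 4 the estimated value is 8000 nM, with an expected range of 2500 nM to 25000 nM.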

Compound 4, concentration for 50% growth inhibition: 100000 nM
Compound 4: middle estimate off by 13-fold (1.10 log units), on the low side, and the stated range ends below it.
By their numbers in this assay, from the lowest: compound 3; then compound 1; then compound 2; then compound 4.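

Placing 2-fluoro-4-(trifluoromethyl)phenyl on this double-bonded chain carbon gives a 25-fold higher number from compound 3 to compound 4 (1.40 log units; beyond the scatter) in this assay, and a 9.1-fold higher number from compound 1 to compound 4 (0.96 log units; beyond the scatter), so this position can respond to a change of ring substituents more sharply than the chloro steps showed. Even the singly substituted 4-chlorophenyl ring compares favourably, with a 2.0-fold higher number from compound 2 to compound 4 (0.31 log units; beyond the scatter), which leaves compound 4 the weakest of the four. Nothing available explains this loss. From the compounds shown here alone, whether it follows the fluoro or the trifluoromethyl group remains open. So does how a ring carrying a methoxy group or an amine would compare.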